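This account rests on a few compounds, and the source may have more. Where it says the series, first, only, none or still open, it means among the compounds named here.

Among the measured compounds shown here, compound 1 `O=C(CN1CCN(c2ccc(Cl)cc2)CC1)N1CCN(c2nnc(-c3ccccc3)c(-c3ccccc3)n2)CC1` is the only member of this small set with a measured number: in a functional assay on MCF7 cells (Homo sapiens) for cytotoxicity, read by MTT assay, with a stated time of 24 h (on this read-out higher numbers stand for weaker inhibition and lower numbers for stronger inhibition), compound 1 gives 56300 nM. Compound 2 `O=C(CN1CCN(c2ccc([N+](=O)[O-])cc2)CC1)N1CCN(c2nnc(-c3ccccc3)c(-c3ccccc3)n2)CC1` carries nitro in place of chloro on an aromatic carbon. In this assay compound 2 reaches only the limit of the assay, > 886000 nM. That change produced an at least 15-fold higher number from compound 1 to compound 2 (1.19 log units; beyond the scatter). Compound 3 `O=C(CN1CCN(c2ccc(Cl)cc2)CC1)N1CCN(c2nnc(-c3ccc(Cl)cc3)c(-c3ccc(Cl)cc3)n2)CC1` differs from compound 1 in its core, and the difference between the two cores is not broken down here. In this assay compound 3 likewise returns only a limit, > 803000 nM. Compound 4 `O=C(CN1CCN(c2ccc([N+](=O)[O-])cc2)CC1)N1CCN(c2nnc(-c3ccc(Cl)cc3)c(-c3ccc(Cl)cc3)n2)CC1` is the unmeasured partner of compound 3, bearing (nitro in place of chloro on an aromatic carbon), the same change as from compound 1 to compound 2. Because compound 3 already stands at the limit of > 803000 nM in this assay, at which 1 of the 3 values shown sits, and because that change gave an at least 15-fold higher number from compound 1 to compound 2 (1.19 log units; beyond the scatter), compound 4 is expected to make a step that the limit leaves unreadable from compound 3 to compound 4. The estimate for compound 4 is 950000 nM, most probably reported again only as a limit.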

Compound 4, half-maximal inhibitory concentration: > 789000 nM
Compound 4 gave a limit, no number; the forecaster's own chance of this, stated with the estimate: 85%; the middle value is on the limit's open side.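

Compound 3 and compound 4 both return only limits of the assay, and the step between them cannot be read. The compounds shown leave open whether nitro in place of chloro changes anything on the core of compound 3.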